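A few compounds are considered here, and "the series" means these few. Any claim that something is new, unique, unknown or untested is made for them only; others in the source may bear on it.

In a functional assay on MCF7 cells (Homo sapiens) for inhibition, read by sulforhodamine B assay, with a stated time of 48 h (a higher number here means that more compound is tolerated, a lower number that less compound is tolerated), compound 1 `COc1cc(-c2cc(/C=C/C(=O)c3ccc(N)cc3)[nH]n2)cc(OC)c1OC` gives 60500 nM, the higher of two actual numbers, and compound 3 `COc1ccc(C(=O)/C=C/c2cc(-c3cc(OC)c(OC)c(OC)c3)n[nH]2)cc1` gives 7610 nM. Compound 2 `COc1cc(-c2cc(/C=C/C(=O)c3ccc(Cl)c(Cl)c3)[nH]n2)cc(OC)c1OC` reaches only a limit of the assay, > 100000 nM. Compound 4 `COc1cc(-c2cc(/C=C/C(=O)c3ccc(F)c(F)c3)[nH]n2)cc(OC)c1OC`, not yet measured, differs from compound 1 on a carbonyl carbon: 3,4-difluorophenyl in place of 4-aminophenyl on a carbonyl carbon. The closest measured change is the 3,4-dichlorophenyl replacement, an at least 1.6-fold higher number from compound 1 to compound 2 (0.21 log units; that floor lies within the scatter). The methoxy replacement gave a modest step, an 8.0-fold lower number from compound 1 to compound 3 (0.90 log units; beyond the scatter), and a large one appears in an at least 13-fold lower number from compound 2 to compound 3 (1.11 log units; beyond the scatter). Since the closest change rests on the first of these steps, no step beyond the scatter is expected in this assay. The estimated step is a 1.2-fold lower number from compound 1 to compound 4 (0.08 log units; within the scatter). Compound 4 is estimated at 50000 nM, with an expected range of 14000 nM to 100000 nM.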

Compound 4, concentration lethal to 50% of the cells: > 100000 nM
Compound 4 ended at the assay's limit (the forecaster's own chance of this, stated with the estimate: 25%); middle value at least 2.0-fold (0.30 log units) from the limit.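

In this assay, the 3,4-difluorophenyl group of compound 4 behaves like the 3,4-dichlorophenyl group of compound 2, as both compounds give a limit and not a number: the limit of > 100000 nM in this assay, at which 2 of the 4 values shown sit. Measured against the 4-aminophenyl group, the change stays small, an at least 1.6-fold higher number from compound 1 to compound 4 (0.21 log units; that floor lies within the scatter), while against the 4-methoxyphenyl group it is large, an at least 13-fold higher number from compound 3 to compound 4 (1.11 log units; beyond the scatter). The step between compound 2 and compound 4 cannot be read.

The compounds shown leave open whether a phenyl group carrying a hydroxyl or a nitrile on this carbonyl carbon would sit with compound 3 or with compound 2 and compound 4.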